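Trifluoromethyl for Chloro on the Core of Compound 2

The source may report more compounds than this note shows. Statements on the series, on what has been measured and on what is new or still open speak of the compounds shown alone.

Compound 1 `FC(F)(F)Oc1ccccc1Oc1ccnc(N2CCC(NC(=S)Nc3cccnc3)CC2)c1Cl` gives 96 nM in an assay on membranes from brain for binding affinity to Lysophosphatidylserine lipase ABHD12 (Mus musculus), read by fluorescence, with a stated time of 20 min; on this read-out higher numbers stand for weaker inhibition and lower numbers for stronger inhibition. Compound 2 `FC(F)(F)Oc1ccc(Oc2ccnc(N3CCC(NC(=S)Nc4cccnc4)CC3)c2Cl)cc1` gives 25 nM in this assay. Compound 3 `FC(F)(F)Oc1ccc(Oc2ccnc(N3CCC(NC(=S)Nc4cccnc4)CC3)c2Cl)cc1Cl` gives 33 nM in this assay.

Compound 2 sits at the low end of these three numbers. Its gap to compound 3 is small, a 1.3-fold higher number from compound 2 to compound 3 (0.12 log units; within the scatter), so the two cannot be ranked against each other. The remaining step is larger: a 3.8-fold lower number from compound 1 to compound 2 (0.58 log units; beyond the scatter).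

Compound 4 `FC(F)(F)Oc1ccc(Oc2ccnc(N3CCC(NC(=S)Nc4cccnc4)CC3)c2C(F)(F)F)cc1` arises from compound 2 by the change (trifluoromethyl in place of chloro on an aromatic carbon). Among the measured compounds shown here, no measured step touches this part of the shared core: the three measured compounds differ only in the aryl ether portion, and the one step that swaps chloro for hydrogen, a 1.3-fold higher number from compound 2 to compound 3 (0.12 log units; within the scatter), sits on a different ring and stays within the scatter. For the measured compounds named here, there is thus no direct precedent for the exchange, and the expectation rests on the absence of large effects from small substituent changes seen so far.

Compound 4 is therefore expected to give about 35 nM in this assay, within a range of 12 nM to 100 nM. This estimate corresponds to a 1.4-fold higher number from compound 2 to compound 4 (0.15 log units; within the scatter), a step not expected to exceed the scatter.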

Compound 4, half-maximal inhibitory concentration: 2800 nM
The estimate for compound 4 lay 80-fold (1.90 log units) below the measured number, outside the stated range (above it).
By their numbers in this assay, from the lowest: compounds 2 and 3 (each within the scatter of the next); then compound 1; then compound 4.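

In this assay, the aromatic carbon that carries chloro in compound 2 proves highly sensitive to this exchange: trifluoromethyl in place of chloro gives a 110-fold higher number from compound 2 to compound 4 (2.05 log units; beyond the scatter), a far larger step than any among compounds 1, 2 and 3. Those compounds differ only in the aryl ether portion, so they showed nothing about this carbon, which lies ortho to two large groups and two atoms from the ring nitrogen. The data shown offer no measurement that accounts for this loss.

From the compounds shown here alone, whether methyl, bromo or a nitrile on this carbon would stay close to compound 2 or fall toward compound 4 remains open. Going by these compounds, it is also open whether trifluoromethyl here would have as large an effect alongside the aryl ether of compound 1 or compound 3.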